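Compound 2 gains a methoxy group: what to expect

The source may report more compounds than this note shows. Statements on the series, on what has been measured and on what is new or still open speak of the compounds shown alone.

compound 1 `Cc1ccc2ncc(S(=O)(=O)c3ccc(F)cc3)c(N3CCC(C)CC3)c2c1`: 90%
compound 2 `CC1CCN(c2c(S(=O)(=O)c3cccc(Cl)c3)cnc3ccc(Cl)cc23)CC1`: 92%
compound 3 `Cc1cc(C)cc(S(=O)(=O)c2cnc3ccc(C)cc3c2N2CCC(C)CC2)c1`: 80%

Of the compounds shown here, three sharing one core have been tested in an assay on isolated protein for displacement of a labelled ligand from metabotropic glutamate receptor 5 (Homo sapiens), with a stated time of 60 min, tested at 1 uM; a lower number here means less inhibition, a higher number more inhibition at the concentration tested (going by the name of the read-out). Compound 2 holds the highest of the three numbers; compound 1 lies nearest, within the scatter, while compound 3 lies beyond the scatter below it. For the measured compounds named here, the single one-place step among them, a number 10 percentage points lower from compound 1 to compound 3 (within the scatter), exchanges 4-fluorophenyl for 3,5-dimethylphenyl on a sulfonyl sulfur and stays within the scatter.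

Compound 4 `COc1ccc(S(=O)(=O)c2cnc3ccc(Cl)cc3c2N2CCC(C)CC2)cc1Cl` differs from compound 2 by methoxy in place of hydrogen on an aromatic carbon. That change also touches the ring on the sulfonyl sulfur, the same region altered in a number 10 percentage points lower from compound 1 to compound 3 (within the scatter), where a larger exchange of substituents moved the number only within the scatter. On that basis the step is expected to be a number 4 percentage points lower from compound 2 to compound 4 (within the scatter), no change beyond the scatter. Compound 4 is therefore estimated at 88% in this assay, with a range from 76% to 97%.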

Compound 4, a percentage reported as inhibition, at one concentration (the size of the read-out at that concentration, not a potency): 46%
For compound 4 the middle estimate is 42 percentage points above the measured one; the measured number lies below the stated range.
By their numbers in this assay, from the lowest: compound 4; then compounds 3, 1 and 2 (each within the scatter of the next, the first and the last beyond it).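

In this assay, for the compounds shown here, the ring on the sulfonyl sulfur proves less forgiving than the earlier compounds suggested: going from 3-chlorophenyl to 3-chloro-4-methoxyphenyl gives a number 46 percentage points lower from compound 2 to compound 4 (beyond the scatter) and so shows that this single added group can matter greatly. The earlier step on this ring, from 4-fluorophenyl to 3,5-dimethylphenyl, was a number 10 percentage points lower from compound 1 to compound 3 (within the scatter) and exchanged more atoms, so among these compounds the number of atoms changed does not tell how far the number moves. No measurement shown here accounts for the loss.

Going by these compounds, it remains open whether the loss belongs to methoxy itself or would follow any group placed ortho to a chloro group and para to a large group. A hydroxyl group or a longer ethoxy chain at this place would help separate these possibilities, as would methoxy on a ring without the chloro group.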